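The source may hold more compounds than are shown below. What is called first, only, known or untested is meant among the compounds shown, and "the series" means these compounds.

Compound 1 `O=C(Nc1cccc(-n2cc(-c3ccncc3)c(-c3ccc(Cl)c(O)c3)n2)c1)Nc1cccc(C(F)(F)F)c1`, compound 2 `COc1cc(-c2nn(-c3cccc(NC(=O)Nc4cccc(C(F)(F)F)c4)c3)cc2-c2ccncc2)ccc1Cl` and compound 3 `COc1cc(-c2nn(-c3cccc(NC(=O)Nc4ccc(Cl)c(C(F)(F)F)c4)c3)cc2-c2ccncc2)ccc1Cl` were tested in a functional assay on MDA-MB-435 cells (Homo sapiens) for inhibition, read by sulforhodamine B assay, with a stated time of 48 h; on this read-out higher numbers stand for lower toxicity in this test and lower numbers for higher toxicity in this test.

Compound 2 gives 8070 nM in this assay. For compound 1 this assay reports only a limit, > 32500 nM. For compound 3 this assay likewise reports only a limit, > 32500 nM. The change hydrogen in place of methyl on an oxygen on an aromatic ring gives an at least 4.0-fold higher number from compound 2 to compound 1 (0.60 log units; beyond the scatter), and the change chloro in place of hydrogen on an aromatic carbon gives an at least 4.0-fold higher number from compound 2 to compound 3 (0.60 log units; beyond the scatter); both steps are known only as lower bounds because of the limit of > 32500 nM in this assay, at which 2 of the 3 values shown sit.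

Compound 4 `O=C(Nc1cccc(-n2cc(-c3ccncc3)c(-c3ccc(Cl)c(O)c3)n2)c1)Nc1ccc(Cl)c(C(F)(F)F)c1` has not been measured in this assay. It differs from compound 3 by hydrogen in place of methyl on an oxygen on an aromatic ring, which is the same change as that from compound 2 to compound 1; the place of the change is the same in both pairs. Since compound 3 already sits at the limit, and the same change raised the number from compound 2 to compound 1, compound 4 is expected to remain at or beyond that limit, a step that the limit leaves unreadable from compound 3 to compound 4 at the least. The estimate for compound 4 is 60000 nM, with a range from 30000 nM to 200000 nM, and most likely this assay would report only a limit.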

Compound 4, concentration lethal to 50% of the cells: 21500 nM
Compound 4: the middle estimate sits 2.8-fold (0.45 log units) above what was measured, and the stated range ends above it.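

In this assay the change from methoxy to hydroxy gives an at least 1.5-fold lower number from compound 3 to compound 4 (0.17 log units; that floor lies within the scatter) and does not carry over unchanged from one core to the other: the same change on two cores in this assay, an at least 4.0-fold higher number (0.60 log units; beyond the scatter) from compound 2 to compound 1 and an at least 1.5-fold lower number (0.17 log units; that floor lies within the scatter) from compound 3 to compound 4, at least 6.0-fold (0.78 log units) apart, beyond the scatter of two such steps. The addition of chloro gives an at least 1.5-fold lower number from compound 1 to compound 4 (0.17 log units; that floor lies within the scatter) and likewise differs between the two cores: the same change on two cores in this assay, an at least 4.0-fold higher number (0.60 log units; beyond the scatter) from compound 2 to compound 3 and an at least 1.5-fold lower number (0.17 log units; that floor lies within the scatter) from compound 1 to compound 4, at least 6.0-fold (0.78 log units) apart, beyond the scatter of two such steps. Going by these compounds, this shows that neither change can simply be transferred between these cores, but it rests on only four compounds, the floors of both new steps lie within the scatter, and the true sizes of the steps remain unknown, as these comparisons depend on a limit of the assay: the limit of > 32500 nM in this assay, at which 2 of the 4 values shown sit.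

The compounds shown leave open whether a longer chain such as ethyl in place of methyl on the oxygen would follow the methoxy or the hydroxy compounds. They also leave open whether a group such as a nitrile or an amine in place of the added chloro would shift the number in the same way on both cores.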